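Swapping the group on sulfur in compound 3

A few compounds are considered here, and "the series" means these few. Any claim that something is new, unique, unknown or untested is made for them only; others in the source may bear on it.

- compound 1 `Cc1cc(N2CC[C@@H](C)[C@@H](N(C)c3ncnc4[nH]ccc34)C2)n2nc(SCc3ccccc3)nc2n1` gives 13900 nM
- compound 2 `Cc1cc(N2CC[C@@H](C)[C@@H](N(C)c3ncnc4[nH]ccc34)C2)n2nc(SCc3csc4ccc(Cl)cc34)nc2n1` gives > 100000 nM (a limit, not a number)
- compound 3 `Cc1cc(N2CC[C@@H](C)[C@@H](N(C)c3ncnc4[nH]ccc34)C2)n2nc(SCCc3ccccc3)nc2n1` gives 11800 nM

In a functional assay on HGC-27 cells (Homo sapiens) for inhibition, read by MTT assay, with a stated time of 72 h (on this read-out higher numbers stand for weaker inhibition and lower numbers for stronger inhibition), compound 3 gives 11800 nM. Going by the values given here, its only numeric neighbour lies within the scatter of it, so neither of the two ranks ahead, while compound 2 reports only a limit.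

Compound 4 `Cc1cc(N2CC[C@@H](C)[C@@H](N(C)c3ncnc4[nH]ccc34)C2)n2nc(SCc3ccc(F)c(Cl)c3)nc2n1` differs from compound 3 on a saturated chain carbon bound to a sulfur: 3-chloro-4-fluorophenyl in place of benzyl on a saturated chain carbon bound to a sulfur. Cut one bond further out, phenethyl gives way to 3-chloro-4-fluorobenzyl.

Among the compounds with values here, two measured steps bear on this change. Benzyl in place of phenyl at this spot changed little: a 1.2-fold lower number from compound 1 to compound 3 (0.07 log units; within the scatter). The 5-chloro-1-benzothiophen-3-yl group in place of phenyl went much further: an at least 7.1-fold higher number from compound 1 to compound 2 (0.85 log units; beyond the scatter). The incoming 3-chloro-4-fluorophenyl also carries chlorine but keeps a single six-membered aromatic ring, so it may sit between these two cases. In this assay a small move toward a higher number is therefore expected, probably not clearly beyond the scatter. The expected step is a 1.6-fold higher number from compound 3 to compound 4 (0.21 log units; within the scatter). For compound 4 the estimated value is 19000 nM. The expected range runs from 7000 nM to 60000 nM.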

Compound 4, half-maximal inhibitory concentration: > 100000 nM
Compound 4 ended at the assay's limit; the forecaster's own chance of this, stated with the estimate: 12%; middle value at least 5.2-fold (0.72 log units) from the limit.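

In this assay, keeping a single six-membered aromatic ring on the saturated chain carbon bound to a sulfur does not by itself keep the value in the measurable range: an at least 8.4-fold higher number from compound 3 to compound 4 (0.92 log units; beyond the scatter), and an at least 7.1-fold higher number from compound 1 to compound 4 (0.85 log units; beyond the scatter). Compound 4 gives a limit and not a number, as does compound 2, so the step between those two cannot be read. Among these four compounds, the fused 5-chloro-1-benzothiophen-3-yl group of compound 2 is therefore not alone, and the two groups carrying chlorine both sit at the ceiling while the plain benzyl and phenethyl groups stay measurable, with no compound here going against that split: the limit of > 100000 nM in this assay, at which 2 of the 4 values shown sit.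

The compounds shown leave open whether chlorine, fluorine or the pair of them goes with this drop in inhibition, a question that a 3-chlorobenzyl or a 4-fluorobenzyl group on sulfur would help to settle. They also leave open whether a chain ending in an amine or a carboxylic acid at this spot would give a value clearly lower than that of compound 3.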